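Amino for methoxy in a series at the limit

The source may hold more compounds than are shown below. What is called first, only, known or untested is meant among the compounds shown, and "the series" means these compounds.

In a functional assay on KYSE-450 cells (Homo sapiens) for inhibition, read by CCK-8 assay, with a stated time of 48 h (on this read-out lower numbers stand for stronger inhibition and higher numbers for weaker inhibition), compound 1 (`COc1ccc(CN(C(=O)CSC(=S)N2CCc3cc(Br)ccc32)c2cc(OC)c(OC)c(OC)c2)cc1`) gives > 20000 nM as a limit and not a number. Compound 2 (`COc1ccc(CN(C(=O)CSC(=S)N2CCN(C(=O)OC(C)(C)C)CC2)c2cc(OC)c(OC)c(OC)c2)cc1OC`) gives > 20000 nM in this assay and this too is a limit. The series therefore offers only the limit of > 20000 nM in this assay, at which 2 of the 2 values shown sit, as its evidence so far, and compound 2 has no exact starting value.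

Compound 3 (`COc1ccc(CN(C(=O)CSC(=S)N2CCN(C(=O)OC(C)(C)C)CC2)c2cc(OC)c(OC)c(OC)c2)cc1N`) differs from compound 2 by amino in place of methoxy on an aromatic carbon as amino in place of methoxy on an aromatic carbon, turning 3,4-dimethoxybenzyl into 3-amino-4-methoxybenzyl. Among the compounds with values here, no measured pair shows what this exchange does. A modest move toward stronger inhibition is expected, with the estimated step of an at least 3.3-fold lower number from compound 2 to compound 3 (0.52 log units; beyond the scatter) being highly uncertain, and another result at the limit remains quite possible. The estimate for compound 3 is 6000 nM with an expected range from 400 nM to 25000 nM for this measurement.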

Compound 3, half-maximal inhibitory concentration: 208 nM
For compound 3 the middle estimate is 29-fold (1.46 log units) above the measured one, and the stated range ends above it.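

In this assay, the exchange of methoxy for amino, turning 3,4-dimethoxybenzyl into 3-amino-4-methoxybenzyl, gives the series its first exact value and shows an at least 96-fold lower number from compound 2 to compound 3 (1.98 log units; beyond the scatter). A single exchange at this position, ortho to a methoxy group, is thus enough to bring the series off the limit, which neither earlier compound showed. The step can be read only as a lower bound because its starting point is a limit: the limit of > 20000 nM in this assay, at which 2 of the 3 values shown sit.

On these data alone, it remains open whether the effect needs the amino group itself or would also appear with a hydroxyl, a methylamino or an acetamide group at the same place. As far as these compounds go, it is also open whether amino at this position would have a similar effect with the other end of the molecule as it stands in compound 1.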